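Fluoro in place of hydroxy: a working note

This account rests on a few compounds, and the source may have more. Where it says the series, first, only, none or still open, it means among the compounds named here.

Within the data shown here, in a functional assay on L1210 (1565) cells (Mus musculus) for cytotoxicity (on this read-out higher numbers stand for an effect only at larger amounts of compound and lower numbers for an effect already at smaller amounts), compound 1 (`Oc1cc(-c2ccccc2)nc2ccc(Cl)cc12`) gives 0.5 ug/mL and compound 2 (`Oc1ccc2c(O)cc(-c3ccccc3)nc2c1`) gives 0.45 ug/mL with the two numbers within the scatter of each other, so compound 2 stands level with the only other measured compound. Compound 3 (`Oc1cc(-c2ccccc2)nc2cc(F)ccc12`) departs from compound 2 by one change (fluoro in place of hydroxy on an aromatic carbon) with fluoro in place of hydroxy on an aromatic carbon. Among the measured compounds shown here, no measured step isolates a single change, so the expectation rests on thin ground. Compound 1 carries no hydroxy on that carbon and still gives 0.5 ug/mL as its number. In this assay a step within the scatter is therefore expected, leaning slightly toward a higher number (a 1.3-fold higher number from compound 2 to compound 3 (0.12 log units; within the scatter)). For compound 3 the estimated value is 0.6 ug/mL (expected range 0.2 ug/mL to 1.8 ug/mL).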

Compound 3, half-maximal effective concentration: 0.16 ug/mL
Estimate against measurement, compound 3: 3.8-fold (0.57 log units) above; the whole stated range lies above it.
By their numbers in this assay, from the lowest: compound 3; then compounds 2 and 1 (each within the scatter of the next).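

Among these compounds, this is the first change that can be read on its own: fluoro in place of hydroxy on this aromatic carbon brings a 2.8-fold lower number from compound 2 to compound 3 (0.45 log units; beyond the scatter) in this assay and counts as a modest step. The hydroxy at this place, with its hydrogen-bond donor and acceptor, is therefore not required for the effect, since fluoro, which counts neither, gives an effect at smaller amounts of compound. Nothing shown accounts for the size or direction of this step.

As far as these compounds go, it remains open whether the step is particular to fluoro or would also appear with an amine or a methoxy group on the same carbon. Also open, from the compounds shown here alone, is whether fluoro would give a step of this kind on another carbon of the same ring.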